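Cyano for nitro on an anilinopyrimidine thioether

The source may hold more compounds than are shown below. What is called first, only, known or untested is meant among the compounds shown, and "the series" means these compounds.

Measured compounds:
Compound 1, `CC(=O)c1ccc(Nc2ccnc(SCC(=O)c3ccc(Br)cc3)n2)cc1`: 23%
Compound 2, `CCOC(=O)c1ccc(Nc2ccnc(SCC(=O)c3ccc([N+](=O)[O-])cc3)n2)cc1`: 29%

Of the compounds shown here, two sharing the same core have been tested in a functional assay on UACC-62 cells (Homo sapiens) for inhibition, read by sulforhodamine B assay, with a stated time of 48 h, tested at 10 uM; a higher number here means more inhibition of growth at the concentration tested, a lower number less inhibition of growth. Compound 1 gives 23%, while compound 2 gives 29%. These two numbers lie within the usual scatter of each other, so on the numbers shown compound 2 cannot be separated from compound 1; neither can be called the more active of the pair.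

Compound 3, `CCOC(=O)c1ccc(Nc2ccnc(SCC(=O)c3ccc(C#N)cc3)n2)cc1`, has not yet been measured in this assay. It differs from compound 2 in one place: cyano in place of nitro on an aromatic carbon. Within the data shown here, no step between measured compounds is available to show what such an exchange does here, and the two measured compounds differ from each other in two places at once, so their values give no clean guide.

Given that, the step from compound 2 to compound 3 is expected to be small, with no direction beyond the scatter, as a number 3 percentage points lower from compound 2 to compound 3 (within the scatter). Compound 3 is therefore estimated at 26%, with a range from 10% to 42%.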

Compound 3, percent growth inhibition at one concentration: 61%
For compound 3 the middle estimate is 35 percentage points below the measured one; the measured number lies above the stated range.
By their numbers in this assay, from the lowest: compounds 1 and 2 (each within the scatter of the next); then compound 3.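

In this assay, the change from 4-nitrophenyl to 4-cyanophenyl gives a number 32 percentage points higher from compound 2 to compound 3 (beyond the scatter), so this one position can move growth inhibition well beyond the scatter. The earlier pair could not show this, as compound 1 and compound 2 differ in two places at once. The exchange is modest when counted: nitro, with 3 heavy atoms, leaves and cyano, with 2, enters on the same aromatic carbon, neither group bringing a ring or a net charge, and no measurement at hand explains why the read-out responds so strongly.

A single step cannot show how other groups at this position, such as an amine, a carboxylic acid or a methoxy group, would compare with cyano and nitro. On these data alone, it also remains open whether the exchange would give a similar step on a different background, for example with the acetyl group of compound 1 in place of the ethyl ester of compound 2 and compound 3.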